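The source may hold more compounds than are shown below. What is called first, only, known or untested is meant among the compounds shown, and "the series" means these compounds.

Measured compounds in this series:

Compound 1 `Nc1nc(OCc2ccccc2)c2ncn(/C=C3/CC3(CO)CO)c2n1` — in an ADME assay on MOLT-3 cells (Homo sapiens) for cytotoxicity, with a stated time of 7 days (on this read-out higher numbers stand for lower toxicity in this test and lower numbers for higher toxicity in this test), compound 1 gives > 20000 nM
Compound 2 `Nc1nc(N2CCCC2)c2ncn(/C=C3/CC3(CO)CO)c2n1` — in this assay compound 2 gives "not determined" (no result reported)
Compound 3 `CCCNc1nc(N)nc2c1ncn2/C=C1/CC1(CO)CO` — in this assay compound 3 gives "not determined" (no result reported)

The value for compound 1 is a limit of the assay, not a number. Compound 3 therefore stands without any number of its own: the only measured entry in the set is the limit for compound 1, and the other two compounds, compound 3 among them, carry no result. Among the compounds with values here, one point of evidence is available, (the limit of > 20000 nM in this assay, at which 1 of the 3 values shown sits), which shows where the one measured compound sits.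

Compound 4 `CCCOc1nc(N)nc2c1ncn2/C=C1/CC1(CO)CO` is the next compound to be measured. It differs from compound 3 by the following change: propoxy in place of propylamino on an aromatic carbon. Within the data shown here, no measured step exists for this change, so no size or direction can be read from the data; the expectation in this assay is of no difference beyond the scatter. For compound 4 the estimated half-maximal cytotoxic concentration is 30000 nM, with an expected range from 10000 nM to 100000 nM.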

Compound 4, half-maximal cytotoxic concentration: > 20000 nM
Compound 4 was reported as a limit; the forecaster's own chance of this, stated with the estimate: 70%; the middle value is on the limit's open side.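

In this assay compound 4 gives > 20000 nM, which is a limit of the assay. Compound 1 also stands at a limit, so no step can be read from compound 1 to compound 4. The compounds shown leave open any comparison of propoxy with propylamino on the shared core.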